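Adding a Second Chlorine to an Inactive Analog

A few compounds are considered here, and "the series" means these few. Any claim that something is new, unique, unknown or untested is made for them only; others in the source may bear on it.

Three compounds sharing one core were tested in a functional assay on the whole organism (strain CD-1) with Mus musculus as the target, with a stated time of 0.5 h; a higher number here means that more compound is needed for the effect, a lower number that less compound is needed. Compound 1 `CC1(c2ccccc2)CC(=O)N(CC(=O)N2CCN(c3ccccc3F)CC2)C1=O` gives 100 mg/kg, and compound 3 `CC1(c2ccccc2)CC(=O)N(CC(=O)N2CCC(Cc3ccccc3)CC2)C1=O` gives 100 mg/kg, the same value. Compound 2 `CC1(c2ccccc2)CC(=O)N(CC(=O)N2CCN(c3cccc(Cl)c3)CC2)C1=O`, carrying a 3-chlorophenyl group, is recorded as "not active" (no number reported), so no single number places it on the scale, and it stands apart from compounds 1 and 3. The new compound 4 `CC1(c2ccccc2)CC(=O)N(CC(=O)N2CCN(c3cccc(Cl)c3Cl)CC2)C1=O` differs from compound 2 by chloro in place of hydrogen on an aromatic carbon, which turns 3-chlorophenyl into 2,3-dichlorophenyl. No measured step covers this change, so its size in this assay cannot be read off; the expectation is that compound 4 either stays inactive or reaches roughly the level shown by compounds 1 and 3. Compound 4 is estimated at 100 mg/kg, with a range from 30 mg/kg to 300 mg/kg.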

Compound 4, minimum effective dose: 300 mg/kg
Compound 4: the middle estimate sits 3.0-fold (0.48 log units) below what was measured; the range from low to high includes it.
By their numbers in this assay, from the lowest: compounds 1 and 3 (each within the scatter of the next); then compound 4.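

In this assay, chloro in place of hydrogen turns compound 2, recorded as not active, into compound 4, which has a measurable dose; without a number for compound 2, the size of this change cannot be read. Compared with 2-fluorophenyl, 2,3-dichlorophenyl gives a 3.0-fold higher number from compound 1 to compound 4 (0.48 log units; beyond the scatter), so more compound is needed. Nothing shown explains this result. From the compounds shown here alone, it remains open whether 2-chlorophenyl alone would give a measurable dose, and how a methoxy or trifluoromethyl group would compare on this ring.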